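The source may hold more compounds than are shown below. What is called first, only, known or untested is meant among the compounds shown, and "the series" means these compounds.

Measured in a functional assay on MCF7 cells (Homo sapiens) for inhibition, read by trypan blue exclusion, with a stated time of 72 h; on this read-out higher numbers stand for weaker inhibition of growth and lower numbers for stronger inhibition of growth:
- compound 1 `CC/C(=C(\c1ccccc1)c1ccc(NC(=O)C(C)C)cc1)c1ccccc1`: > 30000 nM (a limit, not a number)
- compound 2 `CC/C(=C(\c1ccccc1)c1ccc(NC(=O)C(C)C)cc1)c1ccc(OCc2ccccc2)cc1`: > 30000 nM (a limit, not a number)
- compound 3 `CC/C(=C(/c1ccc(NC(=O)C(C)C)cc1)c1ccc(OC)cc1)c1ccc(O)cc1`: 13600 nM

Within the data shown here, compound 3 holds the only true number in this small set. Compound 1 and compound 2 both rest at the limit of > 30000 nM in this assay, at which 2 of the 3 values shown sit, so neither offers a number to compare with.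

Compound 4 `CC/C(=C(\c1ccccc1)c1ccc(NC(=O)C(C)C)cc1)c1ccc(O)cc1`, not yet measured, differs from compound 3 in one place: hydrogen in place of methoxy on an aromatic carbon. Among the measured compounds shown here, the one measured step, a step that the two limits leave unreadable from compound 1 to compound 2, concerns a different change and has no size to borrow.

One structural comparison remains. Compound 1 and compound 2 lack the hydroxyl group that compound 4 keeps, and compound 3, which also carries it, reads 13600 nM. That makes compound 3 the natural reference, though a single pair of limits cannot establish a rule.

In this assay, the expectation is therefore no shift beyond the usual scatter, leaning if anything towards a higher number, meaning weaker inhibition of growth. The expected move is a 1.2-fold higher number from compound 3 to compound 4 (0.07 log units; within the scatter). Compound 4 is estimated at 16000 nM, with an expected range from 7000 nM to 30000 nM.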

Compound 4, concentration for 50% growth inhibition: 8100 nM
The estimate for compound 4 lay 2.0-fold (0.30 log units) above the measured number, and the stated range covers the measured number.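

In this assay, the methoxy group of compound 3 is not needed for the growth inhibition seen: replacing it with hydrogen gives a 1.7-fold lower number from compound 3 to compound 4 (0.23 log units; within the scatter), so 4-methoxyphenyl and phenyl cannot be told apart here. The result also gives the first readable test of the free hydroxy group, with hydroxy in place of hydrogen giving an at least 3.7-fold lower number from compound 1 to compound 4 (0.56 log units; beyond the scatter), and hydrogen in place of benzyl on that oxygen giving an at least 3.7-fold lower number from compound 2 to compound 4 (0.56 log units; beyond the scatter). These two steps give minimum sizes rather than exact ones, since compound 1 and compound 2 each rest on a limit, not a number: the limit of > 30000 nM in this assay, at which 2 of the 4 values shown sit.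

From the compounds shown here alone, it remains open whether the hydroxy group itself is what matters, which an amine or a carboxylic acid on the same aromatic carbon would help to test. Going by these compounds, it is also open whether a longer chain, such as ethoxy or propoxy in place of methoxy, would still leave the reading in this assay within the usual scatter of compound 3 and compound 4.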